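Swapping Chloro for Methyl on a Second Core

A few compounds are considered here, and "the series" means these few. Any claim that something is new, unique, unknown or untested is made for them only; others in the source may bear on it.

Compound 1 `Cc1ccc2c(c1)CCCN2c1nc(Cl)nc2ccccc12` and compound 3 `COc1ccc2c(c1)CCCCN2c1nc(Cl)nc2ccccc12` both carry a chloro group but rest on different cores; the difference between the two cores is not broken down here. In a functional assay on A549 cells (Homo sapiens) for cytotoxicity, read by sulforhodamine B assay (a higher number here means a weaker inhibitor of growth, a lower number a stronger inhibitor of growth), compound 1 gives 43 nM, while compound 3 gives 191 nM. Compound 2 `Cc1ccc2c(c1)CCCN2c1nc(C)nc2ccccc12` differs from compound 1 in a single place: methyl in place of chloro on an aromatic carbon. In this assay compound 2 gives 211 nM, so this one change produced a 4.9-fold higher number from compound 1 to compound 2 (0.69 log units; beyond the scatter). The numbers for compound 2 and compound 3 lie within the scatter of each other, so nothing separates them.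

Compound 4 `COc1ccc2c(c1)CCCCN2c1nc(C)nc2ccccc12` has not yet been measured. It differs from compound 3 by the same kind of change: methyl in place of chloro on an aromatic carbon. The place of the change is described in exactly the same words for both pairs, so the two changes can be treated as the same change made on two different cores. For the measured compounds named here, the only measured example of it is the step from compound 1 to compound 2, and the expectation for compound 4 rests on that single step alone; whether a different core answers the same way is not known from these compounds.

Compound 4 is therefore expected to show a step of a 4.7-fold higher number from compound 3 to compound 4 (0.67 log units; beyond the scatter) in this assay, because the same change gave a 4.9-fold higher number from compound 1 to compound 2 (0.69 log units; beyond the scatter). Compound 4 is estimated at 900 nM, most likely lying between 350 nM and 2500 nM.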

Compound 4, concentration for 50% growth inhibition: 21 nM
Estimate against measurement, compound 4: 43-fold (1.63 log units) above, outside the stated range (below it).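

On the core of compound 3, the swap of chloro for methyl does the opposite of what it did on the core of compound 1. In this assay the new pair shows a 9.1-fold lower number from compound 3 to compound 4 (0.96 log units; beyond the scatter). The earlier step therefore gave the wrong direction for this core, and the two results disagree by more than ordinary assay scatter can account for, so in this series the effect of this change cannot be carried from one core to the other: the same change on two cores in this assay, a 4.9-fold higher number (0.69 log units; beyond the scatter) from compound 1 to compound 2 and a 9.1-fold lower number (0.96 log units; beyond the scatter) from compound 3 to compound 4, 45-fold (1.65 log units) apart, beyond the scatter of two such steps. This does not show why the two cores answer differently, since they differ from each other in more than one place and these four compounds cannot tie the reversal to any single part of the core.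

From the compounds shown here alone, it remains open how other groups would behave on the aromatic carbon between two ring nitrogen atoms, for example an amine or a nitrile, on each of the two cores. Also open, going by these compounds, is what the same swap would do on a core carrying only one of the differences between these two cores, which would help to show which difference goes with the reversal.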